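This account rests on a few compounds, and the source may have more. Where it says the series, first, only, none or still open, it means among the compounds named here.

Measured in a functional assay on A549 cells (Homo sapiens) for antiproliferative activity, read by MTT assay, with a stated time of 72 h; a higher number here means a weaker inhibitor, a lower number a stronger inhibitor:
- Compound 1 `Nc1ccccc1NC(=O)CCCCCCc1nc(-c2ccccc2)no1`: 23900 nM
- Compound 2 `Cc1ccc(-c2noc(CCCCCCC(=O)Nc3ccccc3N)n2)cc1`: 9170 nM
- Compound 3 `Nc1ccccc1NC(=O)CCCCCCc1nc(-c2ccc(C(F)(F)F)cc2)no1`: > 100000 nM, a limit of the assay and not a number

Compound 2 has the lowest number of the three, and a 2.6-fold lower number from compound 1 to compound 2 (0.42 log units; beyond the scatter). Compound 4 `Cc1ccc(-c2noc(CCCCCCC(=O)C(F)(F)F)n2)cc1` has not yet been measured. It differs from compound 2 on the carbonyl carbon: trifluoromethyl in place of (2-aminophenyl)amino on a carbonyl carbon. For the measured compounds named here, no measured step touches that carbonyl carbon. All three instead exchange a group on an aromatic carbon, so they offer only a rough guide to how far numbers move in this series. They show a 2.6-fold lower number from compound 1 to compound 2 (0.42 log units; beyond the scatter), an at least 4.1-fold higher number from compound 1 to compound 3 (0.62 log units; beyond the scatter) and an at least 10-fold higher number from compound 2 to compound 3 (1.03 log units; beyond the scatter). The exchange in compound 4 is much bigger than any of these. Going by the values given here, with compound 2 at 9170 nM, the best number so far, a rise is more likely than a further fall, and its size is expected to be comparable to the larger steps above. The expected change is a 3.3-fold higher number from compound 2 to compound 4 (0.51 log units; beyond the scatter). For compound 4 the estimated value is 30000 nM, with an expected range of 7000 nM to 100000 nM.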

Compound 4, half-maximal inhibitory concentration: > 100000 nM
Compound 4: only a limit was reported; the forecaster's own chance of this, stated with the estimate: 30%; at least 3.3-fold (0.52 log units) between middle value and limit.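

For the compounds shown here, the first change at the carbonyl carbon shows that this position matters at least as much as the aromatic carbon: putting trifluoromethyl in place of (2-aminophenyl)amino gives an at least 10-fold higher number from compound 2 to compound 4 (1.03 log units; beyond the scatter) in this assay. Compound 4 gives > 100000 nM, which is a limit of the assay and not a number, so the step has a lower bound but no known full size. The methyl group that accompanies the best number in the series does not offset this exchange, and the reading is capped: the limit of > 100000 nM in this assay, at which 2 of the 4 values shown sit.

The exchange removes a six-membered aromatic ring, its amine and the amide hydrogen together, so the compounds shown cannot tell which of these parts counts. A phenylamino group or a carboxylic acid at this carbonyl carbon would help separate them.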